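Nitrile added to the pendant phenyl of compound 2

The source may hold more compounds than are shown below. What is called first, only, known or untested is meant among the compounds shown, and "the series" means these compounds.

Two measured compounds frame this step. In an assay on isolated protein for inhibition of N-acylethanolamine-hydrolyzing acid amidase (Homo sapiens), read by fluorescence, with a stated time of 90 min (a lower number here means a stronger inhibitor, a higher number a weaker inhibitor), compound 1 `COc1cccc(-c2ccc(COC3CN(C#N)C3)cc2)c1OC` gives 0.88 nM. Compound 2 `N#CN1CC(OCc2ccc(Oc3ccccc3)cc2-c2ccccc2)C1` gives 8.5 nM in this assay, the higher of the two numbers; its gap to compound 1 lies beyond the scatter, so compound 2 is the weaker inhibitor of the pair. Compound 3 `N#Cc1ccccc1-c1cc(Oc2ccccc2)ccc1COC1CN(C#N)C1` differs from compound 2 in a single place: cyano in place of hydrogen on an aromatic carbon. Going by the values given here, no measured pair shows this change, so its effect is not known from these data. The shared core and the remaining substituents of compound 2 are kept unchanged. The step of a 1.1-fold lower number from compound 2 to compound 3 (0.03 log units; within the scatter) is expected to stay within the usual scatter, with no clear direction. Compound 3 is therefore estimated at 8 nM in this assay, with a range from 2.5 nM to 25 nM.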

Compound 3, half-maximal inhibitory concentration: 6.6 nM
For compound 3 the middle estimate is 1.2-fold (0.08 log units) above the measured one, within the range that was stated.
By their numbers in this assay, from the lowest: compound 1; then compounds 3 and 2 (each within the scatter of the next).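

In this assay, going by these compounds alone, the change from phenyl to 2-cyanophenyl gives a 1.3-fold lower number from compound 2 to compound 3 (0.11 log units; within the scatter) and provides the first single-place comparison in this set. It shows that a cyano on this aromatic carbon, ortho to a large group, leaves the number indistinguishable from that of the unsubstituted phenyl. No measurement here offers an explanation for this outcome.

On these data alone, whether an amine or a carboxylic acid on the same carbon would also stay within the scatter remains open, as does the outcome of placing a cyano elsewhere on this ring. Compound 1 differs from compound 3 in more than one place, so these compounds do not show which structural feature accounts for the lower number of compound 1 at 0.88 nM in this assay.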